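The source may report more compounds than this note shows. Statements on the series, on what has been measured and on what is new or still open speak of the compounds shown alone.

Compound 1, with the structure `O=C1/C(=C/c2cccc(F)c2)CN(S(=O)(=O)c2ccc(Br)cc2)C/C1=C\c1cccc(F)c1`, and compound 2, with the structure `Cc1ccc(S(=O)(=O)N2C/C(=C\c3ccc(F)cc3)C(=O)/C(=C/c3ccc(F)cc3)C2)cc1`, share a core and differ in several places at once, so their two values can only be set side by side. In a functional assay on SMMC-7721 cells (Homo sapiens) for cytotoxicity, read by MTT assay, with a stated time of 24 h (on this read-out lower numbers stand for stronger inhibition and higher numbers for weaker inhibition), compound 1 gives 11700 nM. In this assay, among the compounds with values here, compound 2 gives 5000 nM, the lower of the two numbers measured so far, and compound 1 stands above it by a gap beyond the usual scatter.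

Compound 3, with the structure `N#Cc1ccc(S(=O)(=O)N2C/C(=C\c3ccc(F)cc3)C(=O)/C(=C/c3ccc(F)cc3)C2)cc1`, has not yet been measured in this assay. Its change from compound 2 is a single one: cyano in place of methyl on an aromatic carbon. No pair of measured compounds differing only at that spot exists, so the size of this step has no precedent among the numbers shown. With a single group exchanged at one aromatic carbon, a modest step is expected, with no clear direction and quite possibly none beyond the scatter.

On that basis, compound 3 is estimated to give 5500 nM in this assay, in a range from 2200 nM to 14000 nM. The step this estimate means is a 1.1-fold higher number from compound 2 to compound 3 (0.04 log units; within the scatter), expected to be small.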

Compound 3, half-maximal inhibitory concentration: 15000 nM
Beside the measured number, compound 3's estimate is 2.7-fold (0.44 log units) below it; measured number above the stated range.
By their numbers in this assay, from the lowest: compound 2; then compounds 1 and 3 (each within the scatter of the next).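

Cyano in place of methyl on an aromatic carbon, para to a large group, gives a 3.0-fold higher number from compound 2 to compound 3 (0.48 log units; beyond the scatter) in this assay and is the first single exchange on this core that can be read. It shows that this position is not indifferent in this assay: going from 4-methylphenyl to 4-cyanophenyl on the sulfonyl moves the number towards weaker inhibition, by more than the usual scatter. Nothing measured here accounts for the direction or size of this step.

A single pair cannot show whether the step is particular to cyano or would recur with other groups on this aromatic carbon, such as an amine, a methoxy group or a carboxylic acid. The compounds shown also leave open whether the same exchange would bring a similar step if the other groups on the shared core were different.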